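Cytotoxicity limits in the biaryl amide series, step to compound 4

The source may hold more compounds than are shown below. What is called first, only, known or untested is meant among the compounds shown, and "the series" means these compounds.

Measured so far:
- compound 1, `CC(C)Oc1cccc(-c2ccc(C(=O)N(Cc3cccc(OCCCCCC(=O)O)c3)C(C)C)cc2)c1`: > 26000 nM
- compound 2, `CCOC(=O)CCCCCOc1cccc(CN(C(=O)c2ccc(-c3cccnc3)cc2)C(C)C)c1`: > 26000 nM
- compound 3, `CCOC(=O)CCCCCOc1cccc(CN(C(=O)c2ccc(-c3cc4ccccc4n3S(=O)(=O)c3ccccc3)cc2)C(C)C)c1`: > 26000 nM

In an ADME assay on Raji cells (Homo sapiens) for cytotoxicity, read by CellTiter-Glo and resazurin assay, with a stated time of 72 h (a lower number here means that less compound is needed, a higher number that more compound is needed for the effect), compound 1 gives > 26000 nM, which is a limit of the assay and not a number. In this assay compound 2 likewise gives > 26000 nM, again a limit rather than a measured value. In this assay compound 3 also returns > 26000 nM, a limit. So compound 2 stands where every measured compound of the series stands: at the limit of > 26000 nM in this assay, at which 3 of the 3 values shown sit. Going by the values given here, no step between two measured compounds can be sized, since no compound has given a number.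

Compound 4, `CCOC(=O)CCCCCOc1cccc(CN(C(=O)c2ccc(-c3cc(F)cc(OC)c3)cc2)C(C)C)c1`, is not yet measured. It differs from compound 2 as follows: 3-fluoro-5-methoxyphenyl in place of pyridin-3-yl on an aromatic carbon. The change sits on an aromatic carbon of a six-membered aromatic ring of carbon only.

Among the compounds with values here, with three limits and no measured step, there is no basis for expecting a change beyond the scatter in this assay. Compound 4 is expected to return a limit again, so the step that the limit leaves unreadable from compound 2 to compound 4 is estimated as none beyond the scatter. Compound 4 is accordingly estimated at 30000 nM, with a range from 10000 nM to 100000 nM.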

Compound 4, half-maximal effective concentration: > 26000 nM
Compound 4 was reported as a limit (the forecaster's own chance of this, stated with the estimate: 85%); the middle value lies beyond the limit too.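

In this assay compound 4 gives > 26000 nM, a limit of the assay and not a number. Compound 2 also stands at a limit, so no step can be read between compound 2 and compound 4. The compounds shown leave open what concentration any of them would need for the effect: the limit of > 26000 nM in this assay, at which 4 of the 4 values shown sit.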